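Moving a Chlorine on the Urea Phenyl Ring

This account rests on a few compounds, and the source may have more. Where it says the series, first, only, none or still open, it means among the compounds named here.

Measured compounds:
- compound 1 `O=C(Nc1cccc(CNc2nccnc2Cl)c1)NC1CCCC1` gives > 40000 nM in a functional assay on T-24 cells (Homo sapiens) for antiproliferative activity, read by MTT assay, with a stated time of 48 h; on this read-out lower numbers stand for stronger inhibition and higher numbers for weaker inhibition; this is a limit of the assay, not a number.
- compound 2 `O=C(Nc1cccc(CNc2nccnc2Cl)c1)Nc1ccc(Cl)cc1Cl` gives 5740 nM in this assay.

For the measured compounds named here, compound 2 therefore holds the only real number in the set, since the other value shown is only a limit (the limit of > 40000 nM in this assay, at which 1 of the 2 values shown sits). Going by the values given here, the one measured step, an at least 6.9-fold lower number from compound 1 to compound 2 (0.84 log units; beyond the scatter), shows that a 2,4-dichlorophenyl in place of cyclopentyl on an amide-type nitrogen brings the number down by a clear margin.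

Compound 3 `O=C(Nc1cccc(CNc2nccnc2Cl)c1)Nc1ccc(Cl)c(Cl)c1` is the next compound, and it differs from compound 2 as follows: 3,4-dichlorophenyl in place of 2,4-dichlorophenyl on an amide-type nitrogen. The two compounds have the same atoms joined differently.

Among the compounds with values here, no measured step swaps one dichlorophenyl for another, so the step from compound 1 to compound 2 speaks only to the gain from having a dichlorophenyl at all, not to where its chlorines sit. On that basis the change is expected to leave the number roughly where compound 2 stands, with any shift staying within the scatter. For compound 3 the estimate is 4500 nM, with a range from 1500 nM to 13000 nM, which means an expected step of a 1.3-fold lower number from compound 2 to compound 3 (0.11 log units; within the scatter).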

Compound 3, half-maximal inhibitory concentration: 5210 nM
Compound 3: the middle estimate sits 1.2-fold (0.06 log units) below what was measured, and the stated range covers the measured number.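

Swapping the 2,4-dichlorophenyl for the 3,4-dichlorophenyl on the amide-type nitrogen, with the same atoms joined differently, gives two compounds that cannot be told apart in this assay (a 1.1-fold lower number from compound 2 to compound 3 (0.04 log units; within the scatter)), so for these two chlorine patterns, moving one chlorine makes no readable difference. The advantage over the cyclopentyl group is also not tied to one chlorine pattern, since the second dichlorophenyl shows a step of the same kind (an at least 7.6-fold lower number from compound 1 to compound 3 (0.88 log units; beyond the scatter)), and this is something compound 2 alone could not show. That step has an open end, as the value of compound 1 is a limit and not a number: the limit of > 40000 nM in this assay, at which 1 of the 3 values shown sits.

As far as these compounds go, with both compounds still in the micromolar part of the scale, what remains open is whether either chlorine is needed at all, which a plain phenyl ring or a phenyl ring with a single chlorine would test. From the compounds shown here alone, it is also open whether other groups on this ring, such as methoxy or trifluoromethyl, would lower the number beyond the scatter, or whether only the presence of an aromatic ring on this nitrogen counts.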